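From Hydroxyethyl Amide to Glycinamide on a Shared Core

A few compounds are considered here, and "the series" means these few. Any claim that something is new, unique, unknown or untested is made for them only; others in the source may bear on it.

Compound 1, `O=C(NCCO)c1cccc(-c2cccc3cc(Cc4cccc(C(F)(F)F)c4)sc23)c1`, gives 37.2 nM in a functional assay on CHO cells for agonist activity at G-protein coupled receptor 52 (Homo sapiens), read by AlphaScreen and cAMP accumulation, with a stated time of 30 min; a higher number here means that more compound is needed for the effect, a lower number that less compound is needed.
Compound 2, `Cc1c(Cc2cccc(C(F)(F)F)c2)oc2c(-c3cccc(C(=O)NCCO)c3)cccc12`, gives 81.3 nM in this assay.

Of these two numbers, compound 1 holds the lowest; compound 2 shows a higher number, and the gap lies beyond the usual scatter, so compound 1 needs less material for the effect. Within the data shown here, no pair of measured compounds differs in only one place, so no measured step guides the next change.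

Compound 3, `NC(=O)CNC(=O)c1cccc(-c2cccc3cc(Cc4cccc(C(F)(F)F)c4)sc23)c1`, keeps the core of compound 1 and alters only the amide tail: carbamoyl in place of hydroxymethyl on a saturated chain carbon bound to an amide-type nitrogen. The departing and entering groups are both neutral and each brings a hydrogen-bond donor and acceptor, as the counted difference shows. Among the measured compounds shown here, with no measured step to lean on, the step from compound 1 to compound 3 is expected to be a 1.5-fold higher number from compound 1 to compound 3 (0.17 log units; within the scatter), a modest drift toward a higher number, near the edge of the scatter. Compound 3 is therefore estimated at 55 nM in this assay, with a range from 15 nM to 200 nM.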

Compound 3, half-maximal effective concentration: 55 nM
Beside the measured number, compound 3's estimate shows no gap at the digits printed; measured number inside the range.
By their numbers in this assay, from the lowest: compounds 1, 3 and 2 (each within the scatter of the next, the first and the last beyond it).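

Among these compounds, this is the first measured step that touches only the amide tail on the shared core: in this assay, carbamoyl in place of hydroxymethyl on a saturated chain carbon bound to an amide-type nitrogen gives a 1.5-fold higher number from compound 1 to compound 3 (0.17 log units; within the scatter). At this place, then, a 2-hydroxyethyl tail and a carbamoylmethyl tail give numbers within the scatter of each other, and the two exchanged groups carry the same count of hydrogen-bond donors and acceptors and no net charge. No measurement shown here speaks to what lies behind this result.

As far as these compounds go, whether a tail ending in an amine or a carboxylic acid, or a longer chain, would keep the number within the scatter remains open. Also open, from the compounds shown here alone, is whether carbamoylmethyl would give a similar step on the core of compound 2.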